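Moving the Bromine Across Two Related Cores

This account rests on a few compounds, and the source may have more. Where it says the series, first, only, none or still open, it means among the compounds named here.

Measured compounds in an ADME assay on NHDF cells (Homo sapiens) for cytotoxicity, read by MTT assay, with a stated time of 72 h; on this read-out higher numbers stand for weaker inhibition and lower numbers for stronger inhibition:
Compound 1, `COc1cccc(/C=C2\CCC/C(=C\c3cccc(Br)c3)C2=O)c1OC`: 23900 nM
Compound 2, `COc1cccc(/C=C2\CCC/C(=C\c3ccc(Br)cc3)C2=O)c1OC`: 21400 nM
Compound 3, `COc1ccc(/C=C2\CCC/C(=C\c3cccc(Br)c3)C2=O)cc1OC`: 12400 nM

Compound 2 differs from compound 1 by 4-bromophenyl in place of 3-bromophenyl on a double-bonded chain carbon bound to a double-bonded ring carbon. This gave a 1.1-fold lower number from compound 1 to compound 2 (0.05 log units; within the scatter), so the two sit within the scatter of each other in this assay. Compound 3 shares no single counted difference with compound 1; how the two cores differ is not broken down here. Its value in this assay lies within the scatter of both compound 1 and compound 2.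

Compound 4, `COc1ccc(/C=C2\CCC/C(=C\c3ccc(Br)cc3)C2=O)cc1OC`, is not yet measured. It differs from compound 3 by 4-bromophenyl in place of 3-bromophenyl on a double-bonded chain carbon bound to a double-bonded ring carbon, the same change that took compound 1 to compound 2. Because a 1.1-fold lower number from compound 1 to compound 2 (0.05 log units; within the scatter) was within the scatter, a similarly small step is expected, a 1.1-fold lower number from compound 3 to compound 4 (0.05 log units; within the scatter). Compound 4 is therefore estimated at 11000 nM, with a likely range from 6000 nM to 22000 nM.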

Compound 4, half-maximal inhibitory concentration: 13100 nM
Beside the measured number, compound 4's estimate is 1.2-fold (0.08 log units) below it; low and high end bracket the measured number.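

In this assay, swapping 3-bromophenyl for 4-bromophenyl on the second core gave a 1.1-fold higher number from compound 3 to compound 4 (0.02 log units; within the scatter), a step too small to tell apart from the ordinary spread of repeat measurements. Set beside the same change on the first core, the two steps do not differ: the same change on two cores in this assay, a 1.1-fold lower number (0.05 log units; within the scatter) from compound 1 to compound 2 and a 1.1-fold higher number (0.02 log units; within the scatter) from compound 3 to compound 4, 1.2-fold (0.07 log units) apart, within the scatter of two such steps. This shows that the change carried over between these two cores as a step within the scatter, but two cores are too few to support a rule for the wider series, and nothing here shows that it would hold on a third.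

From the compounds shown here alone, whether a phenyl bearing an amine or a carboxylic acid instead of bromine would also give so small a step in this assay remains open.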